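A few compounds are considered here, and "the series" means these few. Any claim that something is new, unique, unknown or untested is made for them only; others in the source may bear on it.

Values in a functional assay on HeLa cells (Homo sapiens) for inhibition, read by MTT assay, with a stated time of 48 h (a higher number here means a weaker inhibitor, a lower number a stronger inhibitor), so far
- compound 1 `COc1ccc(C(c2c[nH]c3ccc(Br)cc23)c2c[nH]c3ccc(Br)cc23)cc1` gives 5500 nM
- compound 2 `COc1ccc(C(c2c[nH]c3ccc(Br)cc23)c2c[nH]c3ccc(Br)cc23)c(OC)c1` gives 63200 nM
- compound 3 `Brc1ccc2[nH]cc(C(c3c[nH]c4ccc(Br)cc34)C3CCCCC3)c2c1` gives 3200 nM

Compound 3 cannot be told apart from compound 1, since the data show a 1.7-fold lower number from compound 1 to compound 3 (0.24 log units; within the scatter). Both stand well clear of compound 2, and the comparison with compound 3 gives a 20-fold lower number from compound 2 to compound 3 (1.30 log units; beyond the scatter).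

The next compound is compound 4 `O=[N+]([O-])c1ccc(C(c2c[nH]c3ccc(Br)cc23)c2c[nH]c3ccc(Br)cc23)cc1`, which keeps the shared core and changes one group on the central carbon. The difference is 4-nitrophenyl in place of cyclohexyl on a saturated chain carbon bound to two aromatic carbons. In words, 4-nitrophenyl takes the place of cyclohexyl on a saturated chain carbon bound to two aromatic carbons.

The closest guide is compound 1, which also carries a singly substituted phenyl ring at this place, here 4-methoxyphenyl. Its exchange for cyclohexyl gave a 1.7-fold lower number from compound 1 to compound 3 (0.24 log units; within the scatter), so a similar swap may change little. Compound 2 gives a warning, as one added methoxy produced an 11-fold higher number from compound 1 to compound 2 (1.06 log units; beyond the scatter). Going by the values given here, no measured compound carries a nitro group, so the range must stay wide, especially upward.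

The expected outcome in this assay is a 1.9-fold higher number from compound 3 to compound 4 (0.27 log units; within the scatter), which means no step beyond the scatter is expected. For compound 4 the estimated value is 6000 nM, with an expected range from 2000 nM to 20000 nM.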

Compound 4, half-maximal inhibitory concentration: 1500 nM
Estimate against measurement, compound 4: 4.0-fold (0.60 log units) above; measured number below the stated range.
By their numbers in this assay, from the lowest: compound 4; then compounds 3 and 1 (each within the scatter of the next); then compound 2.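

In this assay, going by these compounds alone, the earlier exchanges at this saturated chain carbon bound to two aromatic carbons either left the number within the scatter or raised it, so compound 4 is the first to show a real gain here, and it is the strongest inhibitor of the four. Changing one group on the phenyl ring, with nitro in place of methoxy, gives a 3.7-fold lower number from compound 1 to compound 4 (0.56 log units; beyond the scatter) and replacing cyclohexyl with 4-nitrophenyl gives a 2.1-fold lower number from compound 3 to compound 4 (0.33 log units; beyond the scatter), so a phenyl ring at this place can outdo cyclohexyl, which compound 1 with its methoxy group did not show, while the span from the doubly substituted ring is a 42-fold lower number from compound 2 to compound 4 (1.62 log units; beyond the scatter). No measurement is at hand that explains why nitro behaves differently from methoxy on this ring.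

On these data alone, with only nitro and methoxy on the phenyl ring, it remains open whether a nitrile, a carboxylic acid or an amine in place of the nitro group would give a similar number. As far as these compounds go, it is also open how a plain phenyl ring without any added group would compare with compound 4 in this assay.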